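From 2,4-dimethylphenyl to pyridin-2-yl on a shared core

A few compounds are considered here, and "the series" means these few. Any claim that something is new, unique, unknown or untested is made for them only; others in the source may bear on it.

Of the compounds shown here, three with the same core have been measured in a functional assay on A549 cells (Homo sapiens) for antiproliferative activity, read by MTT assay, with a stated time of 48 h; a higher number here means a weaker inhibitor, a lower number a stronger inhibitor. Compound 1 `O=C(/C=C/c1ccc(O)c(O)c1)N1CCN(c2ccc(F)cc2)CC1` gives 1.25 ug/mL, compound 2 `O=C(/C=C/c1ccc(O)c(O)c1)N1CCN(c2ccccc2Cl)CC1` gives 1.44 ug/mL, and compound 3 `Cc1ccc(N2CCN(C(=O)/C=C/c3ccc(O)c(O)c3)CC2)c(C)c1` gives 1.02 ug/mL. Compound 3 thus stands level with the other two, as both steps that reach it stay within the scatter of repeated measurements: a 1.2-fold lower number from compound 1 to compound 3 (0.09 log units; within the scatter) and a 1.4-fold lower number from compound 2 to compound 3 (0.15 log units; within the scatter).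

Compound 4 `O=C(/C=C/c1ccc(O)c(O)c1)N1CCN(c2ccccn2)CC1` has not yet been measured. It carries pyridin-2-yl in place of 2,4-dimethylphenyl on an amine nitrogen in a ring, the same place that varies among the measured compounds: pyridin-2-yl in place of 2,4-dimethylphenyl on an amine nitrogen in a ring. The third measured step, a 1.2-fold higher number from compound 1 to compound 2 (0.06 log units; within the scatter), also stays within the scatter, so exchanging the group at this place has not yet moved the number measurably in these three compounds. They offer only a partial guide, however, as none of their groups has a nitrogen in the aromatic ring. No step beyond the scatter is expected in this assay, though the range is kept wider than the measured spread. The estimate means a 1.3-fold higher number from compound 3 to compound 4 (0.11 log units; within the scatter), an expected step within the scatter. For compound 4 the estimated value is 1.3 ug/mL, with an expected range from 0.7 ug/mL to 2.6 ug/mL.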

Compound 4, half-maximal inhibitory concentration: 2.32 ug/mL
Compound 4: middle estimate off by 1.8-fold (0.25 log units), on the low side; the range from low to high includes it.
By their numbers in this assay, from the lowest: compounds 3, 1, 2 and 4 (each within the scatter of the next, the first and the last beyond it).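

Until now, no exchange at this place, on an amine nitrogen in a ring, had moved the number in this assay beyond the scatter, but pyridin-2-yl does so in one comparison, with a 2.3-fold higher number from compound 3 to compound 4 (0.36 log units; beyond the scatter) as a modest step. The other two comparisons stay within the scatter, with a 1.6-fold higher number from compound 2 to compound 4 (0.21 log units; within the scatter) and a 1.9-fold higher number from compound 1 to compound 4 (0.27 log units; within the scatter) as their steps, so the position's response to this group is clear only against 2,4-dimethylphenyl. This change replaces a ring of carbon only with a ring holding a hetero atom, and it also adds a hydrogen-bond acceptor and lowers the heavy-atom count, but nothing measured here separates these differences or explains the step.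

The compounds shown leave open whether the ring nitrogen itself matters or whether simply losing the two methyl groups of 2,4-dimethylphenyl would give a similar number, a question that a plain phenyl group at this place would address. They also leave open how pyridin-4-yl or pyrimidin-2-yl would compare, which would show whether the location or number of ring nitrogens counts.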